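This account rests on a few compounds, and the source may have more. Where it says the series, first, only, none or still open, it means among the compounds named here.

Of the compounds shown here, two have so far been read in a functional assay on SW480 cells (Homo sapiens) for inhibition, read by MTT assay, with a stated time of 96 h (a lower number here means a stronger inhibitor, a higher number a weaker inhibitor), and give a first reference point. Compound 1 `CC(=O)O[C@H](CN)CC(=O)O/N=C1C(=C2/C(=O)Nc3ccccc32)/Nc2ccc(O)cc2/1` gives 5600 nM in this assay and compound 2 `NCCO/N=C1C(=C2/C(=O)Nc3ccccc32)/Nc2ccc(O)cc2/1` gives 2500 nM there, the lower of the two numbers. Within the data shown here, the only measured step is a 2.2-fold lower number from compound 1 to compound 2 (0.35 log units; beyond the scatter) and it is modest, though beyond the scatter. That step concerns the group on the oxygen and not the aromatic ring.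

Among the measured compounds shown here, the next compound is compound 3 `NCCO/N=C1C(=C2/C(=O)Nc3ccc(Br)cc32)/Nc2ccc(O)cc2/1` which keeps the chain of compound 2 and carries bromo in place of hydrogen on an aromatic carbon in a part of the molecule where no measured compound differs. The data therefore give no direction for this change. For the measured compounds named here, with a 2.2-fold lower number from compound 1 to compound 2 (0.35 log units; beyond the scatter) as the only guide to size, and that from another place, no step beyond the scatter is expected in this assay. The expected step is a 1.4-fold lower number from compound 2 to compound 3 (0.14 log units; within the scatter) and stays small. For compound 3 the estimate is 1800 nM with an expected range from 600 nM to 5000 nM around it.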

Compound 3, half-maximal inhibitory concentration: 520 nM
Estimate against measurement, compound 3: 3.5-fold (0.54 log units) above; measured number below the stated range.
By their numbers in this assay, from the lowest: compound 3; then compound 2; then compound 1.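

Bromo in place of hydrogen on an aromatic carbon is the first change outside the group on the oxygen with a reading, and in this assay it gives a 4.8-fold lower number from compound 2 to compound 3 (0.68 log units; beyond the scatter) with the chain of compound 2 held constant. The earlier compounds shown here gave no direction for the aromatic ring; this carbon, meta to a fused ring and para to a fused ring, now shows that a single bromine atom in place of hydrogen moves the number beyond the scatter, and downward. No measurement at hand bears on what lies behind this step.

Among the compounds shown, only hydrogen and bromo stand at this carbon, so one step cannot tell whether the result is particular to bromo or would also appear with chloro, fluoro, methyl, methoxy or a nitrile in the same place. Going by these compounds, it also remains open whether bromo would give a step of similar size and direction on the larger group on the oxygen carried by compound 1, or with an amine other than the primary amine of the chain in compound 2.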